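Methylating the Indole Nitrogen of Compound 2

A few compounds are considered here, and "the series" means these few. Any claim that something is new, unique, unknown or untested is made for them only; others in the source may bear on it.

Measured compounds:
compound 1 `CCOc1cc(-c2ccc3[nH]ccc3c2)cn2c(-c3cc(OC)c(OC)c(OC)c3)nnc12`: 589 nM
compound 2 `COc1cc(-c2nnc3c(OC(C)C)cc(-c4ccc5[nH]ccc5c4)cn23)cc(OC)c1OC`: 1250 nM
compound 3 `COc1cc(-c2nnc3c(OC4CCC4)cc(-c4ccc5[nH]ccc5c4)cn23)cc(OC)c1OC`: 232 nM

All three were tested in a functional assay on A549 cells (Homo sapiens) for antiproliferative activity, read by MTT assay, with a stated time of 48 h; on this read-out higher numbers stand for weaker inhibition and lower numbers for stronger inhibition. Compound 2 has the highest number of the three. Its nearest neighbour is compound 1, with a 2.1-fold higher number from compound 1 to compound 2 (0.33 log units; beyond the scatter); its furthest is compound 3, with a 5.4-fold lower number from compound 2 to compound 3 (0.73 log units; beyond the scatter). Between the other two, a 2.5-fold lower number from compound 1 to compound 3 (0.40 log units; beyond the scatter). Each of these steps changes only the group on the oxygen on the aromatic ring.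

Compound 4 `COc1cc(-c2nnc3c(OC(C)C)cc(-c4ccc5c(ccn5C)c4)cn23)cc(OC)c1OC` differs from compound 2 elsewhere: methyl in place of hydrogen on an aromatic nitrogen. Among the measured compounds shown here, none of the measured steps touches this aromatic nitrogen, so no step among the three bears directly on the change, and the measured series gives no direction for it. The expectation is therefore a step of no size beyond the scatter, no change at the digits printed from compound 2 to compound 4 (within the scatter). Compound 4 is accordingly expected to give about 1250 nM in this assay, with a range from 450 nM to 3500 nM that reflects the lack of any comparable step.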

Compound 4, half-maximal inhibitory concentration: 322 nM
Estimate against measurement, compound 4: 3.9-fold (0.59 log units) above; the measured number lies below the stated range.
By their numbers in this assay, from the lowest: compounds 3, 4 and 1 (each within the scatter of the next, the first and the last beyond it); then compound 2.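

In this assay, among the compounds shown here, replacing 1H-indol-5-yl with 1-methyl-1H-indol-5-yl gives a 3.9-fold lower number from compound 2 to compound 4 (0.59 log units; beyond the scatter) and so shows that the read-out also responds at this aromatic nitrogen, whereas the earlier steps changed only the group on the oxygen on the aromatic ring. With isopropyl on that oxygen, the hydrogen on this nitrogen is not required for inhibition in these cells, since the methyl compound gives the lower number. Nothing shown here accounts for the direction or the size of this step.

Compound 4 is the only methylated compound shown, so it remains open whether the same step would appear with ethyl or cyclobutyl on the oxygen. As far as these compounds go, it also remains open how a longer chain or an amine-bearing chain on this nitrogen would read.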